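The source may report more compounds than this note shows. Statements on the series, on what has been measured and on what is new or still open speak of the compounds shown alone.

Of the compounds shown here, three of one series have been measured so far in an assay for inhibition of lanosterol synthase (Rattus norvegicus), using microsomes, tested at 100 nM; a lower number here means less inhibition, a higher number more inhibition at the concentration tested (going by the name of the read-out). Compound 1 `O=C(N1CCN(c2ccncc2Cl)CC1)N1CCN(S(=O)(=O)c2ccc(Cl)cc2)CC1` gives 87% in this assay. Compound 2 `O=C(N1CCN(c2ccncc2Cl)CC1)N1CCN(S(=O)(=O)c2ccc(Br)cc2)CC1` differs from compound 1 only by bromo in place of chloro on an aromatic carbon. In this assay compound 2 gives 100%, so that a number 13 percentage points higher from compound 1 to compound 2 (beyond the scatter). Compound 3 `O=C(N1CCC(c2ccncc2)CC1)N1CCN(S(=O)(=O)c2ccc(Cl)cc2)CC1` carries a different core; how the core of compound 3 differs from the core of compound 1 is not broken down here. In this assay compound 3 gives 91%, a number that sits within the scatter of both compound 1 and compound 2, so no order can be read between them.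

Compound 4 `O=C(N1CCC(c2ccncc2)CC1)N1CCN(S(=O)(=O)c2ccc(Br)cc2)CC1` has not yet been measured. It differs from compound 3 by bromo in place of chloro on an aromatic carbon, the same change that leads from compound 1 to compound 2, in the same place. For the pair compound 1 to compound 2 this change gave a modest rise. The expected step is a number 6 percentage points higher from compound 3 to compound 4 (within the scatter), somewhat smaller than the earlier one. It is smaller because compound 3 already gives 91% and the read-out cannot go much beyond a number that high. The expectation therefore rests on a number 13 percentage points higher from compound 1 to compound 2 (beyond the scatter) and on the already high number of compound 3. Compound 4 is estimated to give 97% in this assay, with the range 89% to 100% expected to hold most repeat measurements.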

Compound 4, a percentage reported as inhibition, at one concentration (the size of the read-out at that concentration, not a potency): 94%
For compound 4 the middle estimate is 3 percentage points above the measured one; measured number inside the range.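

In this assay, putting bromo in place of chloro on the core of compound 3 gives a number 3 percentage points higher from compound 3 to compound 4 (within the scatter). Set beside the same change on the core of compound 1, the two steps cannot be told apart: the same change on two cores in this assay, a number 13 percentage points higher (beyond the scatter) from compound 1 to compound 2 and a number 3 percentage points higher (within the scatter) from compound 3 to compound 4, 10 percentage points apart, within the scatter of two such steps. So nothing here speaks against the change carrying over from one core to the other, but this is not proof that it does: the new step on its own cannot be separated from the ordinary spread of repeat measurements, only two cores are compared, and a percentage at one concentration is not a potency.

The compounds shown carry only chloro or bromo on this six-membered aromatic ring, so they leave open how a different group in the same place, such as methoxy, an amine or a carboxylic acid, would read in this assay. They also leave open whether the step from chloro to bromo would look the same on a third core, or on a core whose number without the change lies well below those of compound 1 and compound 3.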